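A Fluorine Added to the Benzyl Group of Compound 1

This account rests on a few compounds, and the source may have more. Where it says the series, first, only, none or still open, it means among the compounds named here.

Among the compounds with values here, compound 1 `C=C(Br)C(=O)Nc1ccc(/C=C2\SC(=O)N(Cc3ccccc3)C2=O)cc1` is the one compound here with a numerical result: in a functional assay on CCRF-CEM cells (Homo sapiens) for cytotoxicity, read by cell counting, with a stated time of 3 days (a higher number here means a weaker inhibitor, a lower number a stronger inhibitor), compound 1 gives 2300 nM. Compound 2 `Cc1ccc(CN2C(=O)S/C(=C\c3ccc(N)cc3)C2=O)cc1` differs in several places, and in this assay compound 2 gives > 250000 nM, which is a limit of the assay rather than a number (the limit of > 250000 nM in this assay, at which 1 of the 2 values shown sits). Compound 3 `C=C(Br)C(=O)Nc1ccc(/C=C2\SC(=O)N(Cc3cccc(F)c3)C2=O)cc1` differs from compound 1 by fluoro in place of hydrogen on an aromatic carbon. Within the data shown here, no measured pair tests this change, so no step beyond the scatter is expected. Compound 3 is estimated at 2000 nM, between 800 nM and 6000 nM. The expected step of a 1.2-fold lower number from compound 1 to compound 3 (0.06 log units; within the scatter) is small.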

Compound 3, half-maximal inhibitory concentration: 3200 nM
The estimate for compound 3 lay 1.6-fold (0.20 log units) below the measured number, within the range that was stated.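

Replacing hydrogen with fluoro on the benzyl group gives, in this assay, a 1.4-fold higher number from compound 1 to compound 3 (0.14 log units; within the scatter). This is the only pair shown that tests a change at this position, and it shows that 3-fluorobenzyl in place of benzyl leaves the cytotoxicity indistinguishable from that of compound 1. Nothing shown bears on a cause for this result.

Still open, as far as these compounds go, is whether a trifluoromethyl group, a methoxy group or a carboxylic acid at this place on the ring would give a step beyond the scatter.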